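The source may report more compounds than this note shows. Statements on the series, on what has been measured and on what is new or still open speak of the compounds shown alone.

The measured compounds:
compound 1, `CN(C)Cc1ccc2nc(NC(=O)N/N=C3\C(=O)Nc4ccc(F)cc43)sc2c1`, 1550 nM
compound 2, `CC1CCN(Cc2ccc3nc(NC(=O)N/N=C/c4cn(Cc5ccc(Cl)cc5Cl)c5ccccc45)sc3c2)CC1`, 1660 nM
compound 3, `Cc1ccc(Cn2cc(/C=N/NC(=O)Nc3nc4ccc(CN5CCC(C)CC5)cc4s3)c3ccccc32)cc1`, 410 nM

All three were tested in a functional assay on NCI-H460 cells (Homo sapiens) for cytotoxicity, read by MTT assay, with a stated time of 72 h; a lower number here means a stronger inhibitor, a higher number a weaker inhibitor. Compound 1 stands second highest of the three numbers; compound 2 sits within the usual scatter of it, while compound 3 lies beyond the scatter, with the lower number. Compound 4 `CC1CCN(Cc2ccc3nc(NC(=O)N/N=C4\C(=O)Nc5ccc(F)cc54)sc3c2)CC1` differs from compound 1 in one place: 4-methylpiperidin-1-yl in place of dimethylamino on a saturated chain carbon bound to an aromatic carbon. Among the measured compounds shown here, the only measured step, a 4.0-fold lower number from compound 2 to compound 3 (0.61 log units; beyond the scatter), alters a different part of the molecule, so no measured step bears on this change, and no pair with the same core as compound 1 and compound 4 has been compared in this way. Compound 4 is therefore expected to give 1300 nM, within 500 nM to 4000 nM, an estimated step of a 1.2-fold lower number from compound 1 to compound 4 (0.08 log units; within the scatter), nothing beyond the scatter.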

Compound 4, half-maximal inhibitory concentration: 1430 nM
For compound 4 the middle estimate is 1.1-fold (0.04 log units) below the measured one, within the range that was stated.
By their numbers in this assay, from the lowest: compound 3; then compounds 4, 1 and 2 (each within the scatter of the next).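

In this assay, among the compounds shown here, the move to 4-methylpiperidin-1-yl from dimethylamino gives a 1.1-fold lower number from compound 1 to compound 4 (0.03 log units; within the scatter) and so provides the first measured comparison at this place. On the core of compound 1, the ring, with its 7 heavy atoms against 3, leaves the number within the scatter. Nothing measured here explains why the two groups read alike.

Still open, from the compounds shown here alone, is whether a morpholin-4-yl group or a primary amine at this place would read alike. Also open, going by these compounds, is whether dimethylamino would do the same on the core of compound 3.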